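Trifluoromethyl in place of hydrogen: working notes on compound 3

The source may report more compounds than this note shows. Statements on the series, on what has been measured and on what is new or still open speak of the compounds shown alone.

In an ADME assay on the whole organism (plasma) for pharmacokinetics, with Rattus norvegicus as the target (a higher number here means faster removal of the compound, a lower number slower removal), compound 1 `CC1(C)OCc2c(Nc3n[nH]c4ccccc34)nc(-c3cn[nH]c3)nc21` gives 86 mL/min/kg and compound 2 `CC1(C)OCc2c(Nc3n[nH]c4ccc(F)cc34)nc(-c3cn[nH]c3)nc21` gives 81 mL/min/kg. Among the compounds with values here, these two values lie within the scatter of each other, so compound 1 stands level with the only other measured compound.

Compound 3 `CC1(C)OCc2c(Nc3n[nH]c4c(C(F)(F)F)cccc34)nc(-c3cn[nH]c3)nc21` has not yet been measured. It carries trifluoromethyl in place of hydrogen on an aromatic carbon of the core of compound 1 (trifluoromethyl in place of hydrogen on an aromatic carbon). The new group sits on a six-membered aromatic ring of carbon only, ortho to a fused ring and meta to a fused ring.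

Within the data shown here, only one measured step bears on this change: fluoro in place of hydrogen on an aromatic carbon, a 1.1-fold lower number from compound 1 to compound 2 (0.03 log units; within the scatter). Among the measured compounds shown here, that step involves a different group, and no measurement yet covers trifluoromethyl on this core, so the guidance is thin. No step beyond the scatter is therefore expected in this assay, and no firm direction can be assigned. The expected step is a 1.1-fold lower number from compound 1 to compound 3 (0.06 log units; within the scatter). For compound 3 the estimated value is 75 mL/min/kg, with an expected range of 42 mL/min/kg to 115 mL/min/kg.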

Compound 3, clearance: 27 mL/min/kg
For compound 3 the middle estimate is 2.8-fold (0.44 log units) above the measured one; measured number below the stated range.
By their numbers in this assay, from the lowest: compound 3; then compounds 2 and 1 (each within the scatter of the next).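

In this assay, within the data shown here, the aromatic carbon ortho to a fused ring and meta to a fused ring gives the first change that lies beyond the scatter: trifluoromethyl in place of hydrogen brings a 3.2-fold lower number from compound 1 to compound 3 (0.50 log units; beyond the scatter) and so leaves compound 3 at 27 mL/min/kg. Among these compounds, the only earlier step, fluoro in place of hydrogen on an aromatic carbon, gave a 1.1-fold lower number from compound 1 to compound 2 (0.03 log units; within the scatter) and stayed within the scatter, so it did not show that a single substitution on this ring could shift the number at all. Nothing available here bears on why the number falls with this change.

Still open is whether the step belongs to trifluoromethyl itself or to this place on the ring: fluoro is the only other group shown on this ring, and no step links compound 2 with compound 3. Also open, as far as these compounds go, is how methyl, a nitrile, an amine or a carboxylic acid on the same aromatic carbon would read against the hydrogen of compound 1.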